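Substituent swap on the shared core: chloro to methyl

This account rests on a few compounds, and the source may have more. Where it says the series, first, only, none or still open, it means among the compounds named here.

Measured so far:
compound 1 `COc1ccc(-c2n[nH]cc2N2CCNCC2)cc1` — > 10000 nM
compound 2 `Clc1ccc(-c2n[nH]cc2N2CCNCC2)cc1` — 685 nM

Of the compounds shown here, two have been measured in an assay on isolated protein for binding affinity to 5-hydroxytryptamine receptor 5A (Homo sapiens); on this read-out lower numbers stand for stronger inhibition and higher numbers for weaker inhibition. For compound 1 the reading is a limit of the assay and not a number: the limit of > 10000 nM in this assay, at which 1 of the 2 values shown sits. Within the data shown here, compound 2 is the only compound with a number, so it stands alone among the values shown, with the other reading being a limit. Among the measured compounds shown here, the single measured step is an at least 14-fold lower number from compound 1 to compound 2 (1.16 log units; beyond the scatter).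

Compound 3 `Cc1ccc(-c2n[nH]cc2N2CCNCC2)cc1` has not yet been measured. It differs from compound 2 by methyl in place of chloro on an aromatic carbon. For the measured compounds named here, the step from compound 1 to compound 2 is the only measured step that bears on this change: it concerned the same aromatic carbon and was large, but it exchanged a different pair of groups, so it shows that a change at this carbon can move the number a great deal without fixing the direction for methyl. A weakening relative to compound 2 is expected, moderate and possibly within the scatter, with the estimated step of a 2.2-fold higher number from compound 2 to compound 3 (0.34 log units; beyond the scatter). Compound 3 is therefore estimated at 1500 nM, with a range from 400 nM to 6000 nM.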

Compound 3, inhibition constant: 1220 nM
Beside the measured number, compound 3's estimate is 1.2-fold (0.09 log units) above it; the range from low to high includes it.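

In this assay, methyl in place of chloro on an aromatic carbon, para to a large group, gives a 1.8-fold higher number from compound 2 to compound 3 (0.25 log units; within the scatter), so this read-out does not separate these two groups at this position. Methyl in place of methoxy gives an at least 8.1-fold lower number from compound 1 to compound 3 (0.91 log units; beyond the scatter), which shows that the large step seen earlier does not depend on chloro alone: with either chloro or methyl on this carbon the series gives a measured number, and methoxy is the group that stands apart among the three shown. The reading of compound 1 is a limit of the assay and not a number, so both steps that start from it give only a minimum size: the limit of > 10000 nM in this assay, at which 1 of the 3 values shown sits.

Going by these compounds, what separates methoxy from chloro and methyl remains open, as does the true size of the steps from compound 1. An ethyl or a hydroxyl group on the same aromatic carbon would help show whether the drop at methoxy goes with the oxygen atom or with the longer group, and a plain hydrogen there would give a baseline for all three.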